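Shortening the Ether Side Chain: Compound 3 to Compound 4

The source may hold more compounds than are shown below. What is called first, only, known or untested is meant among the compounds shown, and "the series" means these compounds.

Measured compounds in an assay on cells with melanin-concentrating hormone receptor 1 (Homo sapiens) as the target, read by radioligand binding; on this read-out lower numbers stand for stronger inhibition and higher numbers for weaker inhibition:
compound 1, `Nc1ccc2cccc(OC3CCC3)c2n1`: > 2000 nM, a limit of the assay rather than a number
compound 2, `COCC(C)Oc1cccc2ccc(N)nc12`: 606 nM
compound 3, `Nc1ccc2cccc(OCCC3CCCCC3)c2n1`: 808 nM

Compound 3 holds the highest of the two numbers given. Its nearest neighbour is compound 2, whose number lies lower by a margin within the scatter, so no order between compound 2 and compound 3 can be stated. For compound 1 the assay returned only a limit, as recorded in the limit of > 2000 nM in this assay, at which 1 of the 3 values shown sits.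

For the measured compounds named here, the one measured step, an at least 3.3-fold lower number from compound 1 to compound 2 (0.51 log units; beyond the scatter), concerns the group bound directly to the oxygen on the aromatic ring and is at least modest in size.

Compound 4, `CCCCCOc1cccc2ccc(N)nc12`, differs from compound 3 by propyl in place of cyclohexyl on a saturated chain carbon, two bonds along the chain from an oxygen on an aromatic ring. Going by the values given here, no measured step alters a group at that position on the chain; the step from compound 1 to compound 2 bears on it only loosely, since it exchanges a ring for an open chain at a different place. The two measured numbers sit within the scatter of each other, so no direction is indicated. Compound 4 is therefore expected to show no change beyond the scatter, with the estimate a 1.2-fold higher number from compound 3 to compound 4 (0.09 log units; within the scatter). Compound 4 is estimated at 1000 nM, in a range from 300 nM to 4000 nM.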

Compound 4, half-maximal inhibitory concentration: 580 nM
Estimate against measurement, compound 4: 1.7-fold (0.24 log units) above; the range from low to high includes it.
By their numbers in this assay, from the lowest: compounds 4, 2 and 3 (each within the scatter of the next). At a limit, above all of these: compound 1.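

In this assay, the change at this place on the chain gives a 1.4-fold lower number from compound 3 to compound 4 (0.14 log units; within the scatter), so cyclohexyl and propyl, two bonds along the chain from an oxygen on an aromatic ring, cannot be told apart, and the ring can give way to an open end with no readable change. Compared directly on the oxygen, pentyl and 1-(methoxymethyl)ethyl give a 1.0-fold lower number from compound 2 to compound 4 (0.02 log units; within the scatter), which means that the open carbon chain of compound 4 and the oxygen-bearing chain of compound 2 also stand level, and the three side chains of compounds 2, 3 and 4 form one group within the scatter. Pentyl in place of cyclobutyl gives an at least 3.4-fold lower number from compound 1 to compound 4 (0.53 log units; beyond the scatter), a second step beyond the scatter that sets compound 1 apart, though its size rests on a limit of the assay and not on a number: the limit of > 2000 nM in this assay, at which 1 of the 4 values shown sits.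

The compounds shown leave open whether a chain ending in an amine or a carboxylic acid would stay at this level at the same place. They also do not tell whether a longer chain, or a phenyl ring in place of cyclohexyl, would move the number beyond the scatter.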